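This account rests on a few compounds, and the source may have more. Where it says the series, first, only, none or still open, it means among the compounds named here.

Measured compounds:
compound 1, `CCC[C@@H](NC(=O)c1nccs1)c1cnc(Nc2ccc(C)nc2)c(Cl)c1`, 8.2 nM
compound 2, `Cc1ccc(Nc2ncc([C@H](NC(=O)c3nccs3)C3CC3)cc2Cl)cn1`, 9.7 nM
compound 3, `Cc1ccc(Nc2ncc([C@H](NC(=O)c3nccs3)C3CCCCC3)cc2Cl)cn1`, 37.8 nM

In a functional assay on HEK293 cells for negative allosteric modulation of metabotropic glutamate receptor 5 (Homo sapiens), read by HTRF and inositol phosphate accumulation (a higher number here means a weaker inhibitor, a lower number a stronger inhibitor), compound 1 holds the lowest number of the three. Compound 2 sits within the scatter of it, a 1.2-fold higher number from compound 1 to compound 2 (0.07 log units; within the scatter), whereas compound 3 lies further off, a 4.6-fold higher number from compound 1 to compound 3 (0.66 log units; beyond the scatter), and also a 3.9-fold higher number from compound 2 to compound 3 (0.59 log units; beyond the scatter). Every measured step in this set changes the group on the saturated chain carbon bound to the amide-type nitrogen and the aromatic carbon; the rest of the core is held constant throughout.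

Compound 4, `CCC[C@@H](NC(=O)c1nccs1)c1cnc(Nc2ccc(F)nc2)c(Cl)c1`, departs from compound 1 at a different site: fluoro in place of methyl on an aromatic carbon. Among the compounds with values here, no measured pair varies this position, so the set gives no direct guide to the size or direction of the step. The change swaps one heavy atom for another of like size at the far end of the shared core, and the step is therefore expected to be small, a 1.2-fold higher number from compound 1 to compound 4 (0.09 log units; within the scatter), most likely within the scatter. Compound 4 is estimated at 10 nM, with a range of 4 nM to 28 nM.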

Compound 4, half-maximal inhibitory concentration: 12.8 nM
For compound 4 the middle estimate is 1.3-fold (0.11 log units) below the measured one, within the range that was stated.
By their numbers in this assay, from the lowest: compounds 1, 2 and 4 (each within the scatter of the next); then compound 3.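

In this assay the change from 6-methylpyridin-3-yl to 6-fluoropyridin-3-yl gives a 1.6-fold higher number from compound 1 to compound 4 (0.19 log units; within the scatter), so on this aromatic carbon, next to the ring nitrogen and para to a large group, fluoro in place of methyl leaves the number within the scatter. Within the data shown here, this is the first measured step away from the saturated chain carbon, and it shows that the methyl group is not required at this position for a low nanomolar number with propyl on the chain. No measurement at hand bears on why the two groups read alike here.

Still open, going by these compounds, is how larger or different groups at this position would read, such as methoxy, trifluoromethyl or an amine. Also open, on these data alone, is whether fluoro in place of methyl reads the same with cyclopropyl or cyclohexyl on the chain carbon.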